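Sulfonyl aryl variation on the shared core

The source may hold more compounds than are shown below. What is called first, only, known or untested is meant among the compounds shown, and "the series" means these compounds.

Measured so far:
compound 1 `CC(C)OC(=O)N1CCC(Oc2ncnc3c2CCN3c2ccc(S(C)(=O)=O)c(F)c2)CC1`: 109%
compound 2 `CC(C)OC(=O)N1CCC(Oc2ncnc3c2CCN3c2ccc([S+]([O-])N(C)C)cc2)CC1`: 128%

In a functional assay on CHO-K1 cells with Glucose-dependent insulinotropic receptor (Homo sapiens) as the target, read by a luciferase reporter, with a stated time of 5 h (on this read-out lower numbers stand for smaller maximal responses and higher numbers for larger maximal responses), compound 2 gives 128% and stands highest of the two numbers; compound 1 gives 109% in this assay. Among the compounds with values here, the only step recorded, a number 19 percentage points higher from compound 1 to compound 2 (beyond the scatter), shows that exchanging this aryl group moves the response by a modest amount. Compound 3 `Cc1cc(S(C)(=O)=O)ccc1N1CCc2c(OC3CCN(C(=O)OC(C)C)CC3)ncnc21` carries a group of 11 heavy atoms (8 carbon, 2 oxygen, 1 sulfur; one six-membered aromatic ring of carbon only) in place of a group of 11 heavy atoms (8 carbon, 1 nitrogen, 1 oxygen, 1 sulfur; one six-membered aromatic ring of carbon only), on a nitrogen on an aromatic ring in a ring. The entering group holds a methylsulfonyl as the group in compound 1 does, so the change is expected to run back toward compound 1: the expected step is a number 16 percentage points lower from compound 2 to compound 3 (beyond the scatter). Compound 3 is therefore estimated at 112%, between 95% and 132%.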

Compound 3, largest response reached (reported as percent of maximum), in percent of the reference or control that the assay uses: 80%
Compound 3: middle estimate off by 32 percentage points, on the high side, and the stated range ends above it.
By their numbers in this assay, from the lowest: compound 3; then compound 1; then compound 2.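

Keeping the methylsulfonyl does not keep the response: 2-methyl-4-(methylsulfonyl)phenyl in place of 3-fluoro-4-(methylsulfonyl)phenyl gives a number 29 percentage points lower from compound 1 to compound 3 (beyond the scatter), so in this assay this position on the nitrogen responds to more than the sulfonyl group alone. Against the other aryl group the change is larger, a number 48 percentage points lower from compound 2 to compound 3 (beyond the scatter), and compound 3 ends lowest of the three. No measurement at hand accounts for this drop.

Open, from the compounds shown here alone, is whether the loss follows the methyl itself or the absence of the fluorine. A chlorine or methoxy on the aryl ring would help separate these two readings.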